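Ring closure on the amine side chain: cyclohexyl for isobutyl

The compounds below may be only part of what the source reports. "The series", "measured", "known", "first", "only" and "open" are said of these compounds alone.

Compound 1 `COc1cccc(-c2c(C)n(Cc3c(F)cccc3F)c(=O)n(C[C@H](N)C3CCCC3)c2=O)c1F`: 10 nM
Compound 2 `COc1cccc(-c2c(C)n(Cc3c(F)cccc3F)c(=O)n(C[C@@H](N)CC(C)C)c2=O)c1F`: 39 nM

In an assay on HEK293 cells for binding affinity to Gonadotropin-releasing hormone receptor (Homo sapiens), read by radioligand binding (a higher number here means a weaker inhibitor, a lower number a stronger inhibitor), compound 2 stands with the higher of the two numbers, and compound 1 sits lower by a 3.9-fold higher number from compound 1 to compound 2 (0.59 log units; beyond the scatter). Compound 3 `COc1cccc(-c2c(C)n(Cc3c(F)cccc3F)c(=O)n(C[C@H](N)C3CCCCC3)c2=O)c1F` has not been measured; it carries amino(cyclohexyl)methyl in place of 1-amino-3-methylbutyl on a saturated chain carbon bound to an aromatic nitrogen. Among the compounds with values here, the only step that bears on this change is a 3.9-fold higher number from compound 1 to compound 2 (0.59 log units; beyond the scatter), where going from a ring to the open chain raised the number. Closing the chain into a six-membered ring is therefore expected to lower the number for compound 3, by roughly a 3.0-fold lower number from compound 2 to compound 3 (0.48 log units; beyond the scatter). Compound 3 is estimated at 13 nM, with a range from 4 nM to 40 nM.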

Compound 3, inhibition constant: 6.5 nM
For compound 3 the middle estimate is 2.0-fold (0.30 log units) above the measured one; the range from low to high includes it.
By their numbers in this assay, from the lowest: compounds 3 and 1 (each within the scatter of the next); then compound 2.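

Replacing 1-amino-3-methylbutyl with amino(cyclohexyl)methyl gives a 6.0-fold lower number from compound 2 to compound 3 (0.78 log units; beyond the scatter) in this assay. A second carbon ring size therefore goes with a lower number than the open chain, so the result seen with cyclopentyl is not confined to that one ring. Cyclohexyl in place of cyclopentyl gives a 1.5-fold lower number from compound 1 to compound 3 (0.19 log units; within the scatter), so these two rings cannot be told apart here.

Nothing available explains why the rings give lower numbers than the open chain. As far as these compounds go, whether a cyclobutyl or phenyl group would do the same at this place remains open.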